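Swapping Trifluoromethyl for Chloro in Compound 4

The source may report more compounds than this note shows. Statements on the series, on what has been measured and on what is new or still open speak of the compounds shown alone.

Three compounds have been measured in a functional assay on HOP-62 cells (Homo sapiens) for inhibition, read by sulforhodamine B assay, with a stated time of 48 h; a lower number here means a stronger inhibitor of growth, a higher number a weaker inhibitor of growth:

Compound 1, `COc1cc(-c2nn(-c3cccc(NC(=O)Nc4cccc(C(F)(F)F)c4)c3)cc2-c2ccncc2)ccc1Cl`, gives 1340 nM.
Compound 2, `COc1cc(-c2nn(-c3cccc(NC(=O)Nc4ccc(Cl)c(C(F)(F)F)c4)c3)cc2-c2ccncc2)ccc1Cl`, gives 1310 nM.
Compound 3, `O=C(Nc1cccc(-n2cc(-c3ccncc3)c(-c3ccc(Cl)c(O)c3)n2)c1)Nc1ccc(Cl)c(C(F)(F)F)c1`, gives 1220 nM.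

Compound 2 stands second highest of the three numbers, but all three lie within the usual scatter of one another, so no order among them can be claimed. The two measured steps confirm this: a 1.0-fold lower number from compound 1 to compound 2 (0.01 log units; within the scatter), and a 1.1-fold lower number from compound 2 to compound 3 (0.03 log units; within the scatter). Neither change moved the number beyond the scatter.

Compound 4, `COc1cc(-c2nn(-c3cccc(NC(=O)Nc4ccc(Cl)c(Cl)c4)c3)cc2-c2ccncc2)ccc1Cl`, has not yet been measured. It differs from compound 2 in one place: chloro in place of trifluoromethyl on an aromatic carbon.

Going by the values given here, no measured step makes this exact change. Among the compounds with values here, the step that comes nearest is the one from compound 1 to compound 2, which alters the same ring and left the number essentially unchanged. With only that to go on, the expectation for compound 4 in this assay is a number close to that of compound 2, and the estimated step is a 1.0-fold lower number from compound 2 to compound 4 (0.00 log units; within the scatter). Compound 4 is therefore estimated at 1300 nM, with a likely range from 650 nM to 2600 nM.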

Compound 4, concentration for 50% growth inhibition: 1440 nM
Compound 4: middle estimate off by 1.1-fold (0.04 log units), on the low side; low and high end bracket the measured number.
By their numbers in this assay, from the lowest: compounds 3, 2, 1 and 4 (each within the scatter of the next).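

Replacing trifluoromethyl with chloro on this aromatic carbon removes a group of four heavy atoms and leaves one, yet in this assay it gives a 1.1-fold higher number from compound 2 to compound 4 (0.04 log units; within the scatter) and stays within the scatter. Going by these compounds alone, the earlier steps had only added a chloro to this ring or changed the methoxy group on the other aryl ring, so this is the first test of the trifluoromethyl group itself, and here that group can give way to chloro with no measurable shift. Exchanging the whole 3-(trifluoromethyl)phenyl group for 3,4-dichlorophenyl gives a 1.1-fold higher number from compound 1 to compound 4 (0.03 log units; within the scatter) and also stays within the scatter, but nothing measured beyond these growth numbers helps to explain why they stay so close.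

Going by these compounds, both groups at this position carry no hydrogen-bond donors or acceptors, so it remains open whether an amine, a carboxylic acid or a longer alkyl chain on the same carbon would also leave the number in place. On these data alone, with every step on this ring so far lying within the scatter, it is also open which change here, if any, would move the number beyond it.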